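Chloro to Methoxy on Two Cytotoxic Scaffolds

The source may hold more compounds than are shown below. What is called first, only, known or untested is meant among the compounds shown, and "the series" means these compounds.

Compound 1 `O=C(CSC(=S)N[C@H]1CCOC1=O)Nc1ccc(Cl)cc1` was tested in a functional assay on MCF7 cells (Homo sapiens) for cytotoxicity, read by MTT assay, with a stated time of 72 h (a lower number here means a stronger inhibitor, a higher number a weaker inhibitor), where compound 1 gives 50300 nM. Compound 2 `COc1ccc(NC(=O)CSC(=S)N[C@H]2CCOC2=O)cc1` carries methoxy in place of chloro on an aromatic carbon and in this assay compound 2 reaches only > 128000 nM, which is a limit of the assay (the limit of > 128000 nM in this assay, at which 1 of the 3 values shown sits). The step of an at least 2.5-fold higher number from compound 1 to compound 2 (0.40 log units; beyond the scatter). Compound 3 `O=C(CCl)Nc1ccc(C(=O)/C=C/c2cccc(Cl)c2)cc1` rests on a different core; the difference between the two cores is not broken down here. In this assay compound 3 gives 5340 nM, the lowest of the measured numbers. Compound 4 `COc1cccc(/C=C/C(=O)c2ccc(NC(=O)CCl)cc2)c1` repeats the same kind of change, (methoxy in place of chloro on an aromatic carbon), though here the group sits meta to a large group rather than para to a large group. A weakening step is expected, a 2.4-fold higher number from compound 3 to compound 4 (0.39 log units; beyond the scatter), because the earlier step of an at least 2.5-fold higher number from compound 1 to compound 2 (0.40 log units; beyond the scatter) went the same way. Compound 4 is therefore estimated at 13000 nM in this assay, expected to fall between 5000 nM and 40000 nM.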

Compound 4, half-maximal inhibitory concentration: 3020 nM
Estimate against measurement, compound 4: 4.3-fold (0.63 log units) above; measured number outside the range, below it.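

On the core of compound 3, methoxy in place of chloro gives a 1.8-fold lower number from compound 3 to compound 4 (0.25 log units; within the scatter), so in this assay the two groups cannot be told apart on this core. Going by these compounds, the change therefore does not carry over unaltered from the core of compound 1, although a single pair on each core sets no rule for any other core: the same change on two cores in this assay, an at least 2.5-fold higher number (0.40 log units; beyond the scatter) from compound 1 to compound 2 and a 1.8-fold lower number (0.25 log units; within the scatter) from compound 3 to compound 4, at least 4.4-fold (0.65 log units) apart, beyond the scatter of two such steps Compound 2 gives > 128000 nM, which is a limit of the assay and not a number, so the full size of the step on the core of compound 1 stays unknown.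

The compounds shown leave open how an amine or a carboxylic acid in the place of the chloro would fare on either core.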